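From Ethylsulfanyl to Benzylsulfanyl: An Unmeasured Step

The source may report more compounds than this note shows. Statements on the series, on what has been measured and on what is new or still open speak of the compounds shown alone.

Of the compounds shown here, two have been measured in a functional assay on the whole organism (strain NMRI) with Mus musculus as the target, with a stated time of 60 min, at a dose of 20 mg/kg by the intraperitoneal route; on this read-out lower numbers stand for a weaker effect and higher numbers for a stronger effect at the one dose given. Compound 1 `CCSc1nnc(Cc2ccc(Cl)cc2Oc2ccccc2Cl)[nH]1` gives 174%, and compound 2 `CCSc1nnc(Cc2ccc(Cl)cc2Oc2ccccc2F)[nH]1` gives 141%. Compound 2 thus stands lowest of the two numbers, and its nearest neighbour is compound 1, with the step of a number 33 percentage points lower from compound 1 to compound 2 (beyond the scatter) lying beyond the scatter.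

Compound 3 `Fc1ccccc1Oc1cc(Cl)ccc1Cc1nnc(SCc2ccccc2)[nH]1` differs from compound 2 at another place: phenyl in place of methyl on a saturated chain carbon bound to a sulfur. Within the data shown here, the one measured step, fluoro in place of chloro on an aromatic carbon, concerns a different part of the molecule, so no measured step bears on phenyl in place of methyl on a saturated chain carbon bound to a sulfur. With nothing comparable to go on, no step beyond the scatter is expected in this assay in either direction, and the range is set wide.

Compound 3 is therefore estimated at 140%, with a range from 90% to 190%. This estimate means an expected step of a number 1 percentage points lower from compound 2 to compound 3 (within the scatter).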

Compound 3, a percentage reported as activity, at one dose (the size of the read-out at that dose, not a potency): 179%
The estimate for compound 3 lay 39 percentage points below the measured number; low and high end bracket the measured number.
By their numbers in this assay, from the lowest: compound 2; then compounds 1 and 3 (each within the scatter of the next).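

Moving from ethylsulfanyl to benzylsulfanyl gives a number 38 percentage points higher from compound 2 to compound 3 (beyond the scatter) in this assay, so the read-out responds to a change at the sulfur-bound chain and not only to the swap of halogen on the aromatic carbon. This position also accepts a phenyl, with its six carbons and aromatic ring, without any loss of effect at this one dose. Nothing available here explains the rise.

The compounds shown leave open whether the aromatic ring itself matters, or whether a longer saturated chain on the sulfur, such as butyl, would give a similar number. On these data alone, it also remains open how the read-out would respond to a chloro or a methoxy group on the new phenyl ring, or to an amine at the end of the chain.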